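This account rests on a few compounds, and the source may have more. Where it says the series, first, only, none or still open, it means among the compounds named here.

In a functional assay on the whole organism (strain Kunming) with Mus musculus as the target, with a stated time of 30 min (on this read-out higher numbers stand for an effect only at larger amounts of compound and lower numbers for an effect already at smaller amounts), compound 2 `O=c1cc(-c2ccccc2)[nH]c2nc(Cc3ccc(F)cc3)nn12` gives 71.6 mg/kg and compound 1 `Cc1ccc(Cc2nc3[nH]c(-c4ccccc4)cc(=O)n3n2)cc1` gives 65.8 mg/kg, so the two lie within the scatter of each other. Compound 3 `O=c1cc(-c2ccccc2)[nH]c2nc(Cc3ccc(Cl)cc3)nn12` differs from compound 2 by chloro in place of fluoro on an aromatic carbon, para to a large group. Among the measured compounds shown here, the only measured step at this place, a 1.1-fold higher number from compound 1 to compound 2 (0.04 log units; within the scatter), stays within the scatter, and a single step is thin support. No change beyond the scatter is expected in this assay. The expected step is a 1.0-fold lower number from compound 2 to compound 3 (0.01 log units; within the scatter). Compound 3 is estimated at 70 mg/kg, with an expected range of 38 mg/kg to 125 mg/kg.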

Compound 3, dose for half-maximal effect: 61.1 mg/kg
Beside the measured number, compound 3's estimate is 1.1-fold (0.06 log units) above it; measured number inside the range.
By their numbers in this assay, from the lowest: compounds 3, 1 and 2 (each within the scatter of the next).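

In this assay, the change from 4-fluorobenzyl to 4-chlorobenzyl gives a 1.2-fold lower number from compound 2 to compound 3 (0.07 log units; within the scatter) and stays inside the scatter, and replacing methyl with chloro gives a 1.1-fold lower number from compound 1 to compound 3 (0.03 log units; within the scatter) with the same outcome. Methyl, fluoro and chloro on this aromatic carbon, para to a large group, therefore cannot be told apart on this read-out across these three compounds, where earlier only methyl and fluoro could be compared. No available evidence bears on this result.

On these data alone, whether an amine or a carboxylic acid at this place would give a step beyond the scatter remains open. As far as these compounds go, the effect of changes elsewhere on the shared core also remains open.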